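The compounds below may be only part of what the source reports. "The series", "measured", "known", "first", "only" and "open" are said of these compounds alone.

Series notes. Compound 1 `O=C(NS(=O)(=O)c1ccc(F)cc1)c1ccc(Nc2nc(NC3(c4ccc(Cl)cc4)CC3)nc(OCC(F)(F)F)n2)cc1` sets the reference point: in an ADME assay on microsomes from liver (Rattus norvegicus) for metabolic stability, with a stated time of 10 min (a lower number here means that less of the compound is left, a higher number that more of the compound is left), compound 1 gives 99%. Compound 2 `CC(C)(C)NC(=O)NCCS(=O)(=O)NC(=O)c1ccc(Nc2nc(NC3(c4ccc(Cl)cc4)CC3)nc(OCC(F)(F)F)n2)cc1` carries a 2-(((tert-butyl)carbamoyl)amino)ethyl group in place of 4-fluorophenyl on the sulfonyl sulfur, and in this assay compound 2 gives 93%. Among the compounds with values here, the one measured step, a number 6 percentage points lower from compound 1 to compound 2 (within the scatter), leaves the two compounds within the scatter of each other, so compound 2 stands alongside compound 1 with no separation that the data support.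

Compound 3 `CC(C)OC(=O)NCCS(=O)(=O)NC(=O)c1ccc(Nc2nc(NC3(c4ccc(Cl)cc4)CC3)nc(OCC(F)(F)F)n2)cc1` has not been measured. Its change from compound 2 is isopropoxy in place of (tert-butyl)amino on a carbonyl carbon. Within the data shown here, no measured step touches this position; the only step available, from compound 1 to compound 2, altered a different part of the molecule and stayed within the scatter. On that basis no step beyond the scatter is expected, and compound 3 is estimated at a number 1 percentage points lower from compound 2 to compound 3 (within the scatter) relative to compound 2. For compound 3 the expected reading in this assay is 92%, estimated range 78% to 99%.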

Compound 3, percent of the compound remaining: 73%
Compound 3: middle estimate off by 19 percentage points, on the high side, outside the stated range (below it).
By their numbers in this assay, from the lowest: compound 3; then compounds 2 and 1 (each within the scatter of the next).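

At this carbonyl carbon the group does make a difference in this assay: isopropoxy in place of (tert-butyl)amino gives a number 20 percentage points lower from compound 2 to compound 3 (beyond the scatter) and so separates two compounds that share the same chain on the sulfonyl sulfur. Replacing 4-fluorophenyl on the sulfonyl sulfur with 2-((isopropoxycarbonyl)amino)ethyl gives a number 26 percentage points lower from compound 1 to compound 3 (beyond the scatter) as well, so a change at the sulfur can lie beyond the scatter, although the 2-(((tert-butyl)carbamoyl)amino)ethyl group did not show this. Nothing measured here bears on the cause of these steps.

Going by these compounds, whether the step follows the oxygen or the size of the alkyl group remains open, and tert-butoxy and isopropylamino on the same carbonyl carbon would separate the two. Also open, on these data alone, is whether a longer chain on the sulfonyl sulfur would give a similar result.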